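The source may report more compounds than this note shows. Statements on the series, on what has been measured and on what is new or still open speak of the compounds shown alone.

In a physicochemical assay for metabolic stability, read by HPLC, at pH 4.5, tested at 10 uM (a higher number here means that the compound lasts longer, a lower number that the compound disappears faster), compound 1 `O=C(NCCCCc1ccccc1)n1nnc2ccccc21` gives > 2 h, which is a limit of the assay and not a number. Compound 2 `O=C(NCCCCc1ccccc1)n1c(=O)n(C(=O)NCCCCc2ccccc2)c2ccccc21` gives > 2 h, again a limit. Among the compounds with values here, compound 3 `Cc1ccc(CNC(=O)n2c(N)nc3ccccc32)cc1` gives 0.567 h, the only true number among the three, so it stands alone as a reference point. Compound 4 `Nc1nc2ccccc2n1C(=O)NCc1ccccc1` differs from compound 3 in one place: hydrogen in place of methyl on an aromatic carbon. This is hydrogen in place of methyl on an aromatic carbon, turning 4-methylphenyl into phenyl. Within the data shown here, no measured pair of compounds shows what such a change does, so no direction is favoured. The expected step of a 1.0-fold lower number from compound 3 to compound 4 (0.01 log units; within the scatter) stays within the usual scatter of this assay. Compound 4 is estimated at 0.55 h, with an expected range of 0.3 h to 1 h.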

Compound 4, half-life: 0.7 h
Compound 4: middle estimate off by 1.3-fold (0.10 log units), on the low side; the measured number falls inside the stated range.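

In this assay, within the data shown here, the first pair of compounds differing in one place shows a 1.2-fold higher number from compound 3 to compound 4 (0.09 log units; within the scatter) on swapping 4-methylphenyl for phenyl. At this position, para to a large group, the half-lives with methyl and with hydrogen cannot be told apart. Compounds 1 and 2 each carry a limit, not a number, so they could not show this: the limit of > 2 h in this assay, at which 2 of the 4 values shown sit.

On these data alone, whether an amine, a carboxylic acid or a longer chain at this position would also stay within the scatter remains open. So does whether methyl elsewhere on this ring would behave the same way.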